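The compounds below may be only part of what the source reports. "The series", "measured", "known", "first", "only" and "open" are said of these compounds alone.

Three compounds have been measured in a functional assay on HL-60 cells (Homo sapiens) for cytotoxicity, read by luminescence and CellTiter-Glo, with a stated time of 3 days (a higher number here means a weaker inhibitor, a lower number a stronger inhibitor), so far:

Compound 1 `N#Cc1ccc(NC(=O)c2ccc(C(F)(F)F)cc2O)cc1` gives 1030 nM
Compound 2 `N#Cc1ccc(NC(=O)c2cc(C(F)(F)F)ccc2O)cc1` gives 3120 nM
Compound 3 `N#Cc1ccc(NC(=O)c2ccc3cccnc3c2O)c(Cl)c1` gives 910 nM

Compound 1 stands level with compound 3 within the scatter. It stands beyond the scatter from compound 2, whose number 3120 nM is the higher of that pair.

The next compound to be tested is compound 4 `N#Cc1ccc(NC(=O)c2ccc(-c3ccncc3)cc2O)cc1`, which keeps the core of compound 1 but carries pyridin-4-yl in place of trifluoromethyl on an aromatic carbon. Among the measured compounds shown here, no measured pair here differs in one place only, so the data give no direct size for such a change. The three measured numbers do lie fairly close together, which argues against expecting a large jump, though the swap brings in a whole ring and the uncertainty stays wide. In this assay the expected change is a 1.5-fold higher number from compound 1 to compound 4 (0.16 log units; within the scatter) as a small rise in the number that would stay within the scatter. For compound 4 the estimated value is 1500 nM in a range from 300 nM to 6000 nM for the expected result.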

Compound 4, half-maximal inhibitory concentration: 7090 nM
Compound 4: middle estimate off by 4.7-fold (0.67 log units), on the low side; measured number above the stated range.
By their numbers in this assay, from the lowest: compounds 3 and 1 (each within the scatter of the next); then compound 2; then compound 4.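

In this assay, among the compounds shown here, this aromatic carbon, para to a large group and meta to a hydroxy group, proves sensitive to what it carries: pyridin-4-yl in place of trifluoromethyl gives a 6.9-fold higher number from compound 1 to compound 4 (0.84 log units; beyond the scatter), the first step that can be read in one place. The swap changes more than one thing at once, since a six-membered aromatic ring and a hydrogen-bond acceptor enter as trifluoromethyl leaves, and this single step does not separate them. Nothing measured here bears on why the number rises.

On these data alone, it remains open whether phenyl, which has the ring without its nitrogen, would stand nearer to compound 1 or to compound 4. Also open, as far as these compounds go, is how smaller groups at this carbon, such as methyl, chlorine or an amine, would compare with trifluoromethyl.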